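This account rests on a few compounds, and the source may have more. Where it says the series, first, only, none or still open, it means among the compounds named here.

Compound 1, with the structure `COc1ccc(CNC(=O)/C(C#N)=C/c2ccc[nH]2)cc1`, sets the starting point. In a functional assay on MIA cells (Homo sapiens) for inhibition, read by MTT assay, with a stated time of 72 h (on this read-out lower numbers stand for stronger inhibition of growth and higher numbers for weaker inhibition of growth), compound 1 gives only a limit, > 50000 nM, and no number. Compound 2, with the structure `COc1ccc(CNC(=O)/C(C#N)=C/c2cc(Br)co2)cc1`, carries 4-bromofuran-2-yl in place of 1H-pyrrol-2-yl on a double-bonded chain carbon bound to a double-bonded chain carbon, and in this assay compound 2 gives 65000 nM, the only number shown in this study; the step that the limit leaves unreadable from compound 1 to compound 2 cannot be read because of the limit of > 50000 nM in this assay, at which 1 of the 2 values shown sits. Compound 2 therefore stands as the sole measured point on this assay.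

Compound 3, with the structure `COc1ccc(CNC(=O)/C(C#N)=C/c2ccoc2)cc1`, differs from compound 2 by furan-3-yl in place of 4-bromofuran-2-yl on a double-bonded chain carbon bound to a double-bonded chain carbon. Among the measured compounds shown here, no measured step involves this exchange, and the single step on the sheet from compound 1 to compound 2 gives no readable size. The expected step is therefore a 1.2-fold higher number from compound 2 to compound 3 (0.09 log units; within the scatter), within the usual scatter, with a real chance that only a limit is reported. Compound 3 is expected to give 80000 nM, between 30000 nM and 250000 nM.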

Compound 3, concentration for 50% growth inhibition: 8000 nM
The estimate for compound 3 lay 10-fold (1.00 log units) above the measured number; measured number below the stated range.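

In this assay, among the compounds shown here, furan-3-yl in place of 4-bromofuran-2-yl gives an 8.1-fold lower number from compound 2 to compound 3 (0.91 log units; beyond the scatter), the first step at this place whose size can be read, and it lies beyond the scatter. Furan-3-yl in place of 1H-pyrrol-2-yl gives an at least 6.2-fold lower number from compound 1 to compound 3 (0.79 log units; beyond the scatter), so on a double-bonded chain carbon bound to a double-bonded chain carbon, the choice of ring group separates compound 3 from both earlier compounds while the rest of the structure stays the same. The size of this second step is only a minimum, because compound 1 gives a limit and not a number: the limit of > 50000 nM in this assay, at which 1 of the 3 values shown sits.

The exchange between compound 2 and compound 3 removes the bromine and also changes the furan from a 2-yl to a 3-yl group, so these compounds cannot show which of the two changes accounts for the step, and plain furan-2-yl or 5-bromofuran-3-yl would be needed to separate them. They also leave open how a thiophen-3-yl group, or a furan-3-yl group carrying an amine or a carboxylic acid, would read at this place.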